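The compounds below may be only part of what the source reports. "The series", "measured", "known", "first", "only" and "open" are said of these compounds alone.

Measured so far in a functional assay on WI-38 VA13 cells (Homo sapiens) for cytotoxicity; on this read-out lower numbers stand for an effect already at smaller amounts and higher numbers for an effect only at larger amounts of compound:
compound 1 `COc1ccc(C(=O)c2sc3nc(-c4cccs4)ccc3c2N)cc1` gives 0.77 ug/mL
compound 2 `CCC(=O)c1sc2nc(-c3cccs3)ccc2c1N` gives 0.89 ug/mL
compound 3 `COc1cccc(C(=O)c2sc3nc(-c4cccs4)ccc3c2N)c1` gives 0.03 ug/mL

Compound 3 stands lowest of the three numbers: a 26-fold lower number from compound 1 to compound 3 (1.41 log units; beyond the scatter) and a 30-fold lower number from compound 2 to compound 3 (1.47 log units; beyond the scatter) are both large and beyond the scatter, whereas a 1.2-fold higher number from compound 1 to compound 2 (0.06 log units; within the scatter) lies within it. Compound 4 `Nc1c(C(=O)c2ccc(F)c(F)c2)sc2nc(-c3cccs3)ccc12` is not yet measured in this assay. The change is 3,4-difluorophenyl in place of 3-methoxyphenyl on a carbonyl carbon.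

Within the data shown here, no measured step covers the entry of 3,4-difluorophenyl, so the two large steps onto compound 3 are the only guide. They show that what sits on the carbonyl carbon moves this assay strongly, and that two of the three groups tried give numbers far higher than compound 3. With the 3-methoxyphenyl of compound 3 gone, a higher number is expected for compound 4, most likely back toward the range of compound 1 and compound 2, though its size is uncertain; the expected step is a 10-fold higher number from compound 3 to compound 4 (1.00 log units; beyond the scatter). The estimate for compound 4 in this assay is 0.3 ug/mL, with a range from 0.05 ug/mL to 1.5 ug/mL.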

Compound 4, half-maximal effective concentration: > 4 ug/mL
Compound 4: no number, only a limit; the forecaster's own chance of this, stated with the estimate: 5%; middle value at least 13-fold (1.12 log units) away from the limit.
By their numbers in this assay, from the lowest: compound 3; then compounds 1 and 2 (each within the scatter of the next). At a limit, above all of these: compound 4.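

In this assay compound 4 gives a limit and not a number: the limit of > 4 ug/mL in this assay, at which 1 of the 4 values shown sits. Among these compounds, the range at this carbonyl carbon is therefore wider than the earlier compounds showed, with an at least 130-fold higher number from compound 3 to compound 4 (2.12 log units; beyond the scatter), together with an at least 4.4-fold higher number from compound 2 to compound 4 (0.65 log units; beyond the scatter) and an at least 5.1-fold higher number from compound 1 to compound 4 (0.71 log units; beyond the scatter). A six-membered aromatic ring of carbon only on the carbonyl carbon does not by itself give a low number, since compound 1, compound 3 and compound 4 all carry one, and 3,4-difluorophenyl is the only group shown that separates upward from both 4-methoxyphenyl and ethyl.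

As far as these compounds go, the true number for compound 4 stays unknown, so these steps give only their lower bounds. Also open, from the compounds shown here alone, is whether the low number of compound 3 is specific to 3-methoxyphenyl or would persist with 3-hydroxyphenyl, 3-aminophenyl or 3-fluorophenyl on the same carbonyl carbon.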